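Shrinking the Amine Ring on a Quinoline Amide

The source may report more compounds than this note shows. Statements on the series, on what has been measured and on what is new or still open speak of the compounds shown alone.

Measured so far:
compound 1 `O=C(CCc1ccc(C(F)(F)F)cc1)Nc1ccc2nc(N3CC4CCC3C4)ccc2c1` — 1 nM
compound 2 `O=C(CCCCCCCCCCCCc1ccc(C(F)(F)F)cc1)Nc1ccc2nc([N+]34CCC(CC3)CC4)ccc2c1` — 5 nM

In an assay on isolated protein for displacement of a labelled ligand from melanin-concentrating hormone receptor 1 (Homo sapiens) (a higher number here means a weaker inhibitor, a lower number a stronger inhibitor), compound 1 gives 1 nM, the lowest number of the two measured compounds. Compound 2 gives 5 nM in this assay, a higher number by a margin beyond the usual scatter, so compound 1 is the stronger inhibitor of the pair.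

The next compound, compound 3 `O=C(CCc1ccc(C(F)(F)F)cc1)Nc1ccc2nc(N3CCC3)ccc2c1`, keeps the amide and the trifluoromethyl-bearing chain of compound 1 and changes only the amine attached to the shared core: a group of 4 heavy atoms (3 carbon, 1 nitrogen; one four-membered non-aromatic ring with 1 hetero atom) in place of a group of 7 heavy atoms (6 carbon, 1 nitrogen; one five-membered non-aromatic ring of carbon only, one five-membered non-aromatic ring with 1 hetero atom), on an aromatic carbon. Among the compounds with values here, no step between two measured compounds isolates such a change, so the expectation rests on the size of the group alone. A smaller ring in that position is expected to weaken binding somewhat in this assay; the step from compound 1 is estimated at a 10-fold higher number from compound 1 to compound 3 (1.00 log units; beyond the scatter). Compound 3 is therefore expected to give about 10 nM, within a range from 2 nM to 50 nM.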

Compound 3, half-maximal inhibitory concentration: 4 nM
Estimate against measurement, compound 3: 2.5-fold (0.40 log units) above; measured number inside the range.
By their numbers in this assay, from the lowest: compound 1; then compounds 3 and 2 (each within the scatter of the next).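

Within the data shown here, this is the first step in which only the amine on the shared core changes. In this assay, replacing the group of two five-membered rings with the smaller azetidin-1-yl gives a 4.0-fold higher number from compound 1 to compound 3 (0.60 log units; beyond the scatter), so binding responds to this change, yet compound 3 still gives 4 nM and a much smaller ring on this aromatic carbon keeps the compound a potent inhibitor. No measurement shown here explains the loss.

Going by these compounds, with only two amines compared at this position, it remains open whether the number rises steadily as the ring shrinks or whether the shape of the group matters more. A pyrrolidin-1-yl or piperidin-1-yl ring, or an open-chain dimethylamino group, on the same aromatic carbon would be the next comparisons to help decide this.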